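Chloro in Place of Methyl on an Inactive Shared Core

This account rests on a few compounds, and the source may have more. Where it says the series, first, only, none or still open, it means among the compounds named here.

Measured so far:
- compound 1, `CCn1c(/C=C2/C(=O)Nc3ccc(C)cc32)nc2ccccc21`: > 50000 nM (a limit of the assay, not a number)
- compound 2, `Cn1c(/C=C2/C(=O)Nc3ccc(Br)cc32)nc2ccccc21`: > 50000 nM (a limit of the assay, not a number)

Both values come from a functional assay on MCF7 cells (Homo sapiens) for cytotoxicity, read by MTT assay, with a stated time of 48 h; a higher number here means a weaker inhibitor, a lower number a stronger inhibitor. For the measured compounds named here, compound 1 sits at the limit of > 50000 nM in this assay, at which 2 of the 2 values shown sit, so its true potency is unknown beyond the fact that it is weak; compound 2 also reaches only that limit, and no step between the two can be sized. Compound 3, `CCn1c(/C=C2/C(=O)Nc3ccc(Cl)cc32)nc2ccccc21`, keeps the core of compound 1 and differs by one change: chloro in place of methyl on an aromatic carbon. Going by the values given here, with compound 1 giving only a limit, no measured step shows how far this change moves potency, and nothing here suggests a move beyond the scatter. The step that the limit leaves unreadable from compound 1 to compound 3 is expected to be small. Compound 3 is therefore estimated to give 80000 nM in this assay, within 20000 nM to 300000 nM, most likely again reported only as a limit.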

Compound 3, half-maximal inhibitory concentration: > 50000 nM
Compound 3 ended at the assay's limit; the forecaster's own chance of this, stated with the estimate: 85%; the middle value does not contradict the limit.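

For the compounds shown here, compound 1 and compound 3 both end at a limit of the assay rather than at a number, so no step between them can be read: the limit of > 50000 nM in this assay, at which 3 of the 3 values shown sit.

The compounds shown leave open whether chloro in place of methyl changes potency, and whether anything on this shared core gives a measurable value.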